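Swapping the ether-linked bicyclic ring in a prostacyclin receptor series

The compounds below may be only part of what the source reports. "The series", "measured", "known", "first", "only" and "open" are said of these compounds alone.

In an assay on CHO cells for displacement of a labelled ligand from prostacyclin receptor (Homo sapiens), read by scintillation counting, with a stated time of 30 min (a higher number here means a weaker inhibitor, a lower number a stronger inhibitor), the two measured compounds stand as follows:
Compound 1 `Cc1cc(OC[C@@H]2CN(C)c3ccccc3O2)ccc1C(=O)n1c(C)c(CC(=O)O)c2cc(F)ccc21` gives 130 nM.
Compound 2 `Cc1cc(C(=O)n2c(C)c(CC(=O)O)c3cc(F)ccc32)c(C)cc1OC[C@@H]1CN(C)c2ccccc2O1` gives 93 nM.

Within the data shown here, compound 1 has the higher of these two numbers, but the one step between them, a 1.4-fold lower number from compound 1 to compound 2 (0.15 log units; within the scatter), lies within the scatter, so the two compounds cannot be told apart.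

Compound 3 `Cc1cc(OC[C@@H]2COc3ccccc32)ccc1C(=O)n1c(C)c(CC(=O)O)c2cc(F)ccc21` differs from compound 1 by a group of 9 heavy atoms (8 carbon, 1 oxygen; one five-membered non-aromatic ring with 1 hetero atom, one six-membered aromatic ring of carbon only) in place of a group of 11 heavy atoms (9 carbon, 1 nitrogen, 1 oxygen; one six-membered non-aromatic ring with 2 hetero atoms, one six-membered aromatic ring of carbon only), on a saturated chain carbon bound to an oxygen on an aromatic ring. Among the measured compounds shown here, no measured step touches this part of the molecule: the only step in hand, from compound 1 to compound 2, concerns a methyl in place of hydrogen on an aromatic carbon elsewhere and is itself within the scatter, so it says nothing about the change in hand. Lacking any comparable step, the expectation is a number near that of compound 1 with wide uncertainty on either side. For compound 3 the expected step is a 1.5-fold higher number from compound 1 to compound 3 (0.19 log units; within the scatter). Compound 3 is therefore estimated at 200 nM, within a range from 50 nM to 800 nM.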

Compound 3, inhibition constant: 520 nM
The estimate for compound 3 lay 2.6-fold (0.41 log units) below the measured number, within the range that was stated.
By their numbers in this assay, from the lowest: compounds 2 and 1 (each within the scatter of the next); then compound 3.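

Among these compounds, this is the first change that moves the number beyond the scatter: replacing the group on the saturated chain carbon bound to an oxygen on an aromatic ring gives a 4.0-fold higher number from compound 1 to compound 3 (0.60 log units; beyond the scatter). The effect is modest, but it shows that this part of the molecule matters more to the measured number than the methyl step elsewhere did. The swap alters several things at once, as the six-membered non-aromatic ring with 2 hetero atoms gives way to a five-membered one with 1 hetero atom, and nothing available explains the loss.

The compounds shown do not separate the effect of ring size from that of losing the ring nitrogen and its methyl. A six-membered ring with oxygen as its only hetero atom, or a plain phenyl group, would help to pull these apart.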